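Removing a methyl from a chlorinated phenoxy arm

This account rests on a few compounds, and the source may have more. Where it says the series, first, only, none or still open, it means among the compounds named here.

Of the compounds shown here, three sharing one core have been measured in a physicochemical assay for lipophilicity, in phosphate buffer, measured as octanol-water partition; a higher number here means a more lipophilic compound, a lower number a more polar compound. Compound 1 `O=c1c2ccccc2nc(-c2ccccc2)n1/N=C/c1ccc(Oc2ccc([N+](=O)[O-])cc2)cc1` gives 6.12, compound 2 `Cc1ccc(Oc2ccc(/C=N/n3c(-c4ccccc4)nc4ccccc4c3=O)cc2)cc1` gives 6.29, and compound 3 `Cc1cc(Oc2ccc(/C=N/n3c(-c4ccccc4)nc4ccccc4c3=O)cc2)ccc1Cl` gives 6.52, the highest of the three; its gap to compound 2 lies within the scatter, while the step of a number 0.40 log units higher from compound 1 to compound 3 (beyond the scatter) lies beyond it. Compound 4 `O=c1c2ccccc2nc(-c2ccccc2)n1/N=C/c1ccc(Oc2ccc(Cl)cc2)cc1` is not yet measured and differs from compound 3 by one change: hydrogen in place of methyl on an aromatic carbon. Within the data shown here, no measured step removes a methyl alone; the nearest comparisons are a number 0.17 log units higher from compound 1 to compound 2 (within the scatter) and a number 0.23 log units higher from compound 2 to compound 3 (within the scatter), both small. One carbon leaving is therefore expected to lower the number only modestly, giving an estimated a number 0.47 log units lower from compound 3 to compound 4 (beyond the scatter). For compound 4 the estimate is 6.05, with a range from 5.7 to 6.4.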

Compound 4, partition coefficient: 6.38
Estimate against measurement, compound 4: 0.33 log units below, within the range that was stated.
By their numbers in this assay, from the lowest: compounds 1, 2, 4 and 3 (each within the scatter of the next, the first and the last beyond it).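

In this assay the step for hydrogen in place of methyl, ortho to a chloro group, is a number 0.14 log units lower from compound 3 to compound 4 (within the scatter) and is the only step shown that removes this one carbon alone. Two further swaps on an aromatic carbon also stay small: chloro in place of methyl gives a number 0.09 log units higher from compound 2 to compound 4 (within the scatter) and chloro in place of nitro gives a number 0.26 log units higher from compound 1 to compound 4 (within the scatter) on the same arm. No measurement at hand explains these steps.

The compounds shown leave open whether an amine or a carboxylic acid on this arm would give a step beyond the scatter.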